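The source may hold more compounds than are shown below. What is called first, only, known or untested is meant among the compounds shown, and "the series" means these compounds.

In a functional assay on HEK293 cells for agonist activity at 5-hydroxytryptamine receptor 7 (Homo sapiens), read by a luciferase reporter and beta-arrestin recruitment, with a stated time of 22 h (a higher number here means that more compound is needed for the effect, a lower number that less compound is needed), compound 1 `COc1ccccc1-c1cc(C2CCN(C)C2)ccc1Cl` gives 646 nM; 650 nM (2 entries), and compound 2 `CNCc1ccc(Cl)c(-c2ccccc2OC)c1` gives 148 nM; 150 nM (2 entries). Compound 3 `CCN(CC)Cc1ccc(Cl)c(-c2ccccc2OC)c1` has no single number in this assay: each of its entries for compound 3 reports "not active" (no number reported), so it stands apart from both, without a value to place it. Compound 4 `CCCNCc1ccc(Cl)c(-c2ccccc2OC)c1` differs from compound 3 by propylamino in place of diethylamino on a saturated chain carbon bound to an aromatic carbon, which gives compound 4 a donor in its amine as compound 2 has. The step from compound 3 to compound 4 in this assay is expected to run toward less compound being needed, but its size cannot be set from a starting point with no number, and no activity remains a possible outcome. Compound 4 is estimated at 500 nM, within a range of 100 nM to 3000 nM.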

Compound 4, half-maximal effective concentration: "not active" (no number reported)
Nothing numeric was reported for compound 4, so the estimate cannot be set against anything.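

In this assay, for the compounds shown here, compound 3 and compound 4 are both reported as not active, so no step between them can be read, and nothing at hand bears on this result. The compounds shown leave open what separates compound 4 from compound 2, which gives a number.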